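The source may report more compounds than this note shows. Statements on the series, on what has been measured and on what is new or still open speak of the compounds shown alone.

Of the compounds shown here, two have so far been measured in a functional assay on cells (T-cell line, Homo sapiens) for inhibition; on this read-out higher numbers stand for weaker inhibition and lower numbers for stronger inhibition. Compound 1 `COc1ccc(CCCN2CCC(CNC(c3ccccc3)c3ccccc3)CC2)cc1` gives 2800 nM, and compound 2 `Clc1ccccc1CCCN1CCC(COC(c2ccccc2)c2ccccc2)CC1` gives 800 nM, so compound 2 holds the lower of the two numbers, with compound 1 sitting above it by a margin beyond the usual scatter. Compound 3 `CCCCCCCCCCN1CCC(COC(c2ccccc2)c2ccccc2)CC1` has not yet been measured. It differs from compound 2 in a single place: heptyl in place of 2-chlorophenyl on a saturated chain carbon, three bonds along the chain from an amine nitrogen in a ring. Within the data shown here, no single-change step between measured compounds exists, so the expectation rests on this structural change alone. For compound 3 a moderately weaker inhibition is expected, a step of a 3.1-fold higher number from compound 2 to compound 3 (0.49 log units; beyond the scatter), with an estimated 2500 nM in this assay, likely between 800 nM and 8000 nM.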

Compound 3, half-maximal inhibitory concentration: 2600 nM
Beside the measured number, compound 3's estimate is 1.0-fold (0.02 log units) below it, within the range that was stated.
By their numbers in this assay, from the lowest: compound 2; then compounds 3 and 1 (each within the scatter of the next).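

Putting heptyl in place of 2-chlorophenyl on the saturated chain carbon weakens inhibition in this assay, with a 3.3-fold higher number from compound 2 to compound 3 (0.51 log units; beyond the scatter), a modest step. This position therefore accepts a chain without a ring, and compound 3 still gives a measurable 2600 nM. No measurement at hand explains the step.

As far as these compounds go, the change removes the aromatic ring and the chlorine together, so their separate contributions remain unknown. A plain phenyl group or a shorter chain such as butyl at this position would be needed to tell them apart.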